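The compounds below may be only part of what the source reports. "The series", "measured", "known", "first", "only" and "open" are said of these compounds alone.

Compound 1 `CC(Sc1nnc(-c2ccncc2)s1)C(=O)NCc1ccccc1Cl` sits at > 50000 nM, which is a limit of the assay. Compound 2 `O=C(CCSc1nnc(-c2ccncc2)s1)Nc1c(Cl)cccc1Cl` gives 12600 nM. Compound 3 `CC(CSc1nnc(-c2ccncc2)s1)C(=O)Nc1c(Cl)cccc1Cl` sits at > 50000 nM, again a limit.

Within the data shown here, in an ADME assay on HepG2 cells (Homo sapiens) for cytotoxicity, with a stated time of 3 days (a higher number here means that more compound is tolerated, a lower number that less compound is tolerated), compound 2 therefore stands as the only number among the three results; the other two sit at the limit of > 50000 nM in this assay, at which 2 of the 3 values shown sit. Compound 4 `O=C(CCSc1nnc(-c2ccncc2)s1)NCc1ccccc1` differs from compound 2 by benzyl in place of 2,6-dichlorophenyl on an amide-type nitrogen. Among the measured compounds shown here, the one measured step, an at least 3.9-fold higher number from compound 2 to compound 3 (0.59 log units; beyond the scatter), concerns a different place on the chain and ends at a limit, so it does not bear directly on this change; no measured pair shows the swap of the amide substituent. With compound 2 as the only numerical anchor, compound 4 is expected to land in the same region or somewhat higher, an estimated 2.0-fold higher number from compound 2 to compound 4 (0.30 log units; within the scatter) to 25000 nM within 7000 nM and 90000 nM.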

Compound 4, half-maximal cytotoxic concentration: 14000 nM
Compound 4: middle estimate off by 1.8-fold (0.25 log units), on the high side; low and high end bracket the measured number.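

In this assay, the change on the amide-type nitrogen gives a 1.1-fold higher number from compound 2 to compound 4 (0.05 log units; within the scatter). Benzyl and 2,6-dichlorophenyl therefore cannot be told apart at this position, which the earlier step, made elsewhere on the chain, could not show. Compound 4 gives a number and not a limit, so this swap does not reach the ceiling that other compounds in the set sit at: the limit of > 50000 nM in this assay, at which 2 of the 4 values shown sit.

As far as these compounds go, whether the two groups would still read alike alongside the chain methyl of compound 3 remains open. Also open, from the compounds shown here alone, is how an amine, a carboxylic acid or a longer chain would read in place of benzyl on the amide-type nitrogen.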